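Combining an Aryl Ether with a Flexible Hydroxamate Linker

The source may report more compounds than this note shows. Statements on the series, on what has been measured and on what is new or still open speak of the compounds shown alone.

Measured compounds:
Compound 1, `Cc1cc(F)cc(C)c1Oc1ccc(C(C)(C)O)cc1-c1cn(C)c(=O)c2[nH]c(C(=O)NCc3ccc(C(=O)NO)cc3)cc12`, gives 39.3 nM.
Compound 2, `CC(C)Oc1ccc(C(C)(C)O)cc1-c1cn(C)c(=O)c2[nH]c(C(=O)NCCCCCCC(=O)NO)cc12`, gives 5.4 nM.

Both compounds were tested in an assay on isolated protein for inhibition of protein deacetylase HDAC6 (Homo sapiens), read by fluorescence; on this read-out higher numbers stand for weaker inhibition and lower numbers for stronger inhibition. Compound 2 has the lower of the two numbers, and the gap to compound 1 lies beyond the usual scatter of this assay. The two compounds differ in two places at once, in the group on the aromatic ether oxygen and in the chain between the amide and the hydroxamic acid, so the shown values do not tell which of the two differences carries the gap.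

Compound 3, `Cc1cc(F)cc(C)c1Oc1ccc(C(C)(C)O)cc1-c1cn(C)c(=O)c2[nH]c(C(=O)NCCCCCCC(=O)NO)cc12`, has not yet been measured. It keeps the chain of compound 2 and differs from it in one place: 4-fluoro-2,6-dimethylphenyl in place of isopropyl on an oxygen on an aromatic ring. Compound 1 carries the same 4-fluoro-2,6-dimethylphenoxy group, and in this assay compound 1 gives 39.3 nM, a weaker value than compound 2, but with the linker also changed this is no clean guide. A modest step toward weaker inhibition, or none beyond the scatter, is expected, a 1.7-fold higher number from compound 2 to compound 3 (0.22 log units; within the scatter). Compound 3 is estimated at 9 nM, within 3 nM to 27 nM.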

Compound 3, half-maximal inhibitory concentration: 17.2 nM
Compound 3: the middle estimate sits 1.9-fold (0.28 log units) below what was measured; low and high end bracket the measured number.
By their numbers in this assay, from the lowest: compound 2; then compound 3; then compound 1.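

With the chain held fixed, the change from isopropyl to 4-fluoro-2,6-dimethylphenyl on an oxygen on an aromatic ring gives in this assay a 3.2-fold higher number from compound 2 to compound 3 (0.50 log units; beyond the scatter) and so shows that the group on this oxygen by itself shifts the read-out beyond the scatter, with isopropoxy the better of the two on this chain. With the 4-fluoro-2,6-dimethylphenoxy group held fixed, 5-(hydroxycarbamoyl)pentyl in place of 4-(hydroxycarbamoyl)phenyl on a saturated chain carbon bound to an amide-type nitrogen gives a 2.3-fold lower number from compound 1 to compound 3 (0.36 log units; beyond the scatter) in the same assay, so the chain also matters on its own, and the gap left unassigned by the first two compounds now has a part at each place. Nothing given here accounts for either step.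

The compounds shown leave open how a methoxy or an unsubstituted phenoxy group would stand on this chain, and thus whether the step follows the ring, its fluorine or its methyl groups. They also leave open how isopropoxy would read on the 4-(hydroxycarbamoyl)phenyl chain, which bears on whether the two changes simply add, and how a shorter or longer chain would compare.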